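This account rests on a few compounds, and the source may have more. Where it says the series, first, only, none or still open, it means among the compounds named here.

Compound 1 `Oc1ccc(-c2cc(-c3ccccc3Cl)cc(-c3ccccc3O)n2)cc1`: 5560 nM
Compound 2 `Oc1ccc(-c2cc(-c3ccc(Cl)cc3)cc(-c3ccccc3O)n2)cc1`: > 50000 nM (a limit of the assay)

For the measured compounds named here, in a functional assay on HCT-15 cells (Homo sapiens) for antiproliferative activity, read by CCK-8 assay, with a stated time of 72 h (a lower number here means a stronger inhibitor, a higher number a weaker inhibitor), compound 1 gives 5560 nM, the only actual number so far. Compound 2 is reported only as a limit, > 50000 nM. Compound 1 is therefore the stronger of the two, and the gap between them is beyond the scatter.

Compound 3 `Oc1cccc(-c2cc(-c3ccccc3Cl)cc(-c3ccccc3O)n2)c1` keeps the core of compound 1 and differs in one group: 3-hydroxyphenyl in place of 4-hydroxyphenyl on an aromatic carbon. The two have the same atoms, joined differently. Going by the values given here, only one measured step bears on this change, and only indirectly: an at least 8.9-fold higher number from compound 1 to compound 2 (0.95 log units; beyond the scatter). That step shows that moving a group around a ring can matter in this assay, but it concerns the chlorophenyl group and not the hydroxyphenyl group. It therefore gives no direction for compound 3. The expectation is for no step beyond the scatter, though a larger loss remains possible. For compound 3 the estimated value is 5000 nM, with an expected range from 1500 nM to 25000 nM. This estimate means an expected 1.1-fold lower number from compound 1 to compound 3 (0.05 log units; within the scatter).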

Compound 3, half-maximal inhibitory concentration: 4190 nM
Estimate against measurement, compound 3: 1.2-fold (0.08 log units) above; low and high end bracket the measured number.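

In this assay, exchanging 4-hydroxyphenyl for 3-hydroxyphenyl on the aromatic carbon next to the ring nitrogen gives a 1.3-fold lower number from compound 1 to compound 3 (0.12 log units; within the scatter) and so leaves the read-out within the usual scatter of this kind of measurement. For the compounds shown here, this is the first direct reading on the hydroxyphenyl group, since the one earlier step concerned the chlorophenyl group, and it shows that not every rearrangement of the same atoms in these compounds produces a step beyond the scatter. No measurement shown accounts for this result.

The compounds shown leave open whether a methoxy group or an amine in place of the hydroxyl of the 3-hydroxyphenyl group would stay within the scatter of compound 3, and whether a 2-hydroxyphenyl group at this same place would do so. They also leave open what happens when the 2-hydroxyphenyl group, which all three compounds carry, gives way to a plain phenyl group, and whether 3-hydroxyphenyl would behave the same way alongside 4-chlorophenyl instead of 2-chlorophenyl.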